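Adding a Second Nitro Group: An Expected Dose

A few compounds are considered here, and "the series" means these few. Any claim that something is new, unique, unknown or untested is made for them only; others in the source may bear on it.

Compound 1, `CCOc1ccccc1-c1ncc(C(=O)O)c(=O)[nH]1`: in a functional assay on the whole organism (strain Sprague-Dawley) for inhibition, with Rattus norvegicus as the target, with a stated time of 10 min (a higher number here means that more compound is needed for the effect, a lower number that less compound is needed), compound 1 gives 0.5 mg/kg.
Compound 2, `CCOc1ccc([N+](=O)[O-])cc1-c1ncc(C(=O)O)c(=O)[nH]1`: compound 2 gives 25 mg/kg.
Compound 3, `CCOC(=O)c1cnc(-c2cc([N+](=O)[O-])ccc2OCC)[nH]c1=O`: compound 3 gives 5 mg/kg.

Compound 2 differs from compound 1 by nitro in place of hydrogen on an aromatic carbon, and that change made a step of a 50-fold higher number from compound 1 to compound 2 (1.70 log units; beyond the scatter). Compound 3 carries ethyl in place of hydrogen on an oxygen next to a carbonyl group relative to compound 2, a step of a 5.0-fold lower number from compound 2 to compound 3 (0.70 log units; beyond the scatter). The difference between the cores of compound 1 and compound 3 is not broken down here.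

Compound 4, `CCOC(=O)c1cnc(-c2cc([N+](=O)[O-])cc([N+](=O)[O-])c2OCC)[nH]c1=O`, is not yet measured; it differs from compound 3 by nitro in place of hydrogen on an aromatic carbon. This is the same kind of change as from compound 1 to compound 2, though the place differs: in compound 2 the nitro sits para to an ethoxy group, while in compound 4 it sits ortho to an ethoxy group and meta to a nitro group. Among the measured compounds shown here, the earlier step is the only guide. For compound 4 a step of a 10-fold higher number from compound 3 to compound 4 (1.00 log units; beyond the scatter) is expected, somewhat smaller than the earlier one, because the same kind of change at its other place gave a 50-fold higher number from compound 1 to compound 2 (1.70 log units; beyond the scatter). Compound 4 is therefore estimated at 50 mg/kg, within a range from 10 mg/kg to 250 mg/kg.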

Compound 4, dose for 50% inhibition: > 50 mg/kg
Compound 4: only a limit was reported; the forecaster's own chance of this, stated with the estimate: 20%; the middle value sits exactly at the limit.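

In this assay, the nitro group, placed here ortho to an ethoxy group and meta to a nitro group, again pushed the number up, with a step of an at least 10-fold higher number from compound 3 to compound 4 (1.00 log units; beyond the scatter). For compound 4, the reported > 50 mg/kg is a limit of the assay and not a number. The change therefore moved the dose in the same direction on both cores, but this does not show that it carries over with the same size, and the two nitro positions also differ: the same change on two cores in this assay, a 50-fold higher number (1.70 log units; beyond the scatter) from compound 1 to compound 2 and an at least 10-fold higher number (1.00 log units; beyond the scatter) from compound 3 to compound 4; the limit leaves it open whether they differ

The compounds shown leave open whether an amine or a nitrile at the same place on the aromatic ring would also raise the dose needed. They also leave open how a nitro group at this place would act without the other nitro group, and how a second nitro group would act on the core of compound 2, which carries a carboxylic acid instead of the ethyl ester.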